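Phenyl in place of pyridin-4-yl in compound 3

The compounds below may be only part of what the source reports. "The series", "measured", "known", "first", "only" and "open" are said of these compounds alone.

In a functional assay on WM-115 cells (Homo sapiens) for cytotoxicity, read by MTT assay, with a stated time of 46 h (a lower number here means a stronger inhibitor, a higher number a weaker inhibitor), compound 1 (`O=C1/C(=C/c2ccncc2)C(c2ccccc2)Oc2ccccc21`) gives 6300 nM and compound 2 (`O=C1/C(=C\c2ccncc2)C(c2ccccc2)Oc2ccccc21`) gives 4600 nM, so compound 2 stands level with compound 1 within the scatter. Compound 3 (`O=C1/C(=C\c2ccccc2)C(c2ccccc2)Oc2ccccc21`) has phenyl in place of pyridin-4-yl on a double-bonded chain carbon bound to a double-bonded ring carbon. Going by the values given here, the only measured step, a 1.4-fold lower number from compound 1 to compound 2 (0.14 log units; within the scatter), changes the double bond alone and gives no size for this exchange. No shift beyond the scatter is expected, and the expected step is a 1.1-fold higher number from compound 2 to compound 3 (0.04 log units; within the scatter). For compound 3 the estimate in this assay is 5000 nM, with an expected range of 1800 nM to 14000 nM.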

Compound 3, half-maximal inhibitory concentration: 52600 nM
Compound 3: the middle estimate sits 11-fold (1.02 log units) below what was measured; the measured number lies above the stated range.
By their numbers in this assay, from the lowest: compounds 2 and 1 (each within the scatter of the next); then compound 3.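

In this assay, phenyl in place of pyridin-4-yl on a double-bonded chain carbon bound to a double-bonded ring carbon gives an 11-fold higher number from compound 2 to compound 3 (1.06 log units; beyond the scatter). This position is therefore sensitive to the exchange of these two six-membered aromatic rings, which differ in one ring nitrogen, a size of effect that the double-bond step alone could not reveal. Nothing available bears on the cause of this step.

On these data alone, whether the same step holds with the double bond drawn E remains open. So does the response to pyridin-3-yl, or to an amine or carboxylic acid on this ring.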